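Working notes on compounds 1 to 3: fluoro to hydrogen

This account rests on a few compounds, and the source may have more. Where it says the series, first, only, none or still open, it means among the compounds named here.

Measured so far in a functional assay on HeLa cells (Homo sapiens) for antiproliferative activity, read by sulforhodamine B assay, with a stated time of 72 h; a lower number here means a stronger inhibitor, a higher number a weaker inhibitor:
- compound 1 `COc1ccc(C)cc1NC(=S)N/N=C/c1ccc2ccccc2n1`: > 100000 nM, a limit of the assay, not a number.
- compound 2 `Fc1ccccc1NC(=S)N/N=C/c1ccc2ccccc2n1`: > 100000 nM, likewise a limit of the assay.

Among the compounds with values here, compound 2 stands at the limit in this assay, and the same holds for the only other value shown, because of the limit of > 100000 nM in this assay, at which 2 of the 2 values shown sit. Within the data shown here, neither measured compound gives a number, so no step between measured compounds can be drawn and no direction of the series is visible.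

Compound 3 `S=C(N/N=C/c1ccc2ccccc2n1)Nc1ccccc1` is the next member and remains to be measured in this assay. The change from compound 2 to compound 3 is hydrogen in place of fluoro on an aromatic carbon. Read one bond further out, it is 2-fluorophenyl to phenyl. A single fluorine is removed and nothing else moves.

The expectation is that the step from compound 2 to compound 3 in this assay is none beyond the scatter, that is a step that the limit leaves unreadable from compound 2 to compound 3, with a high chance that only a limit is again reported. Compound 3 is estimated at 150000 nM, in the range 50000 nM to 500000 nM.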

Compound 3, half-maximal inhibitory concentration: 27400 nM
Estimate against measurement, compound 3: 5.5-fold (0.74 log units) above; the whole stated range lies above it.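

In this assay, hydrogen in place of fluoro on an aromatic carbon, ortho to a large group, gives an at least 3.6-fold lower number from compound 2 to compound 3 (0.56 log units; beyond the scatter), the only readable step among the compounds shown. This position therefore affects the read-out, and the 2-fluorophenyl to phenyl change is enough to bring the series off the limit. Within the data shown here, compound 3 gives 27400 nM, the only true number so far. The true size of the step stays unknown and only its lower bound can be stated, because compound 2 gives no number to measure from: the limit of > 100000 nM in this assay, at which 2 of the 3 values shown sit.

On these data alone, it remains open whether the step is specific to the removal of fluoro or whether other groups on the same aromatic carbon, such as a chlorine, an amine or a carboxylic acid, would also give a number rather than a limit. Also open, as far as these compounds go, is how far the phenyl of compound 3 can be changed at its other ring positions, since a single step on a single ring position sets no trend for the series.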